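The compounds below may be only part of what the source reports. "The series", "measured", "known", "first", "only" and "open" are said of these compounds alone.

Working notes on the series. In a functional assay on HCT-116 cells (Homo sapiens) for antiproliferative activity, read by WST assay, with a stated time of 72 h (a lower number here means that less compound is needed, a higher number that more compound is needed for the effect), compound 1 (`CCCCNCC(=O)Nc1ccc(/C(N)=N/O)cc1`) gives 83000 nM and compound 2 (`CCCCCCNC(=O)Nc1ccc(/C(N)=N/O)cc1`) gives 195000 nM. Compound 2 therefore holds the higher of the two numbers, and the gap to compound 1 lies beyond the scatter. These two compounds differ in more than one place, so the gap does not isolate any single change.

Compound 3 (`CCCCNC(=O)Nc1ccc(/C(N)=N/O)cc1`) is reached from compound 2 by one change: hydrogen in place of ethyl on a saturated chain carbon, four bonds along the chain from an amide-type nitrogen. Among the compounds with values here, no measured pair covers this change, so the expectation rests on little. In this assay, no step beyond the scatter is expected. The estimated step is a 1.1-fold lower number from compound 2 to compound 3 (0.06 log units; within the scatter). For compound 3 the expected value is 170000 nM, with an estimated range of 70000 nM to 400000 nM.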

Compound 3, half-maximal effective concentration: 186000 nM
Compound 3: the middle estimate sits 1.1-fold (0.04 log units) below what was measured; the measured number falls inside the stated range.
By their numbers in this assay, from the lowest: compound 1; then compounds 3 and 2 (each within the scatter of the next).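

In this assay, within the data shown here, hydrogen in place of ethyl on a saturated chain carbon, four bonds along the chain from an amide-type nitrogen, gives a 1.0-fold lower number from compound 2 to compound 3 (0.02 log units; within the scatter), so shortening the chain at this position produces no step that stands out from the scatter. Butylamino in place of (butylamino)methyl on a carbonyl carbon gives a 2.2-fold higher number from compound 1 to compound 3 (0.35 log units; beyond the scatter), a modest step and the first single change in the series to lie beyond the scatter. No supporting data bear on either step.

The compounds shown leave open whether a longer chain at the first position, or a chain ending in an amine or a carboxylic acid, would keep the number unchanged. They also leave open how other groups on the carbonyl carbon, such as a (butylamino)ethyl chain, would compare with compound 1 and compound 3.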